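A Tolyl Group Replaces Dichlorophenyl on a Shared Core

The source may hold more compounds than are shown below. What is called first, only, known or untested is meant among the compounds shown, and "the series" means these compounds.

Of the compounds shown here, three that share one core have been measured in a functional assay on HT-29 cells (Homo sapiens) for cytotoxicity, read by MTT assay, with a stated time of 48 h, tested at 25 uM; a lower number here means a weaker effect, a higher number a stronger effect of the compound at the concentration tested. Compound 1 `CS(=O)(=O)c1ccc(Cc2nnc3n2N=C(c2ccc(-c4ccccc4)cc2)CS3)cc1` gives 60.2%. Compound 2 `CS(=O)(=O)c1ccc(Cc2nnc3n2N=C(c2cc(Cl)sc2S(N)(=O)=O)CS3)cc1` gives 18.7%, and compound 3 `CS(=O)(=O)c1ccc(Cc2nnc3n2N=C(c2ccc(Cl)cc2Cl)CS3)cc1` gives 24.2%. Compound 3 thus stands second highest of the three numbers; its nearest neighbour is compound 2, and the step of a number 5.5 percentage points higher from compound 2 to compound 3 (within the scatter) lies within the scatter, while compound 1 sits beyond the scatter above it. Compound 4 `Cc1ccc(C2=Nn3c(Cc4ccc(S(C)(=O)=O)cc4)nnc3SC2)cc1` differs from compound 3 at a single place: 4-methylphenyl in place of 2,4-dichlorophenyl on a carbon with a double bond to nitrogen. Among the measured compounds shown here, no measured step involves a 4-methylphenyl group. For the measured compounds named here, the only step at the carbon with a double bond to nitrogen, a number 5.5 percentage points higher from compound 2 to compound 3 (within the scatter), shows that exchanging one aryl group for another there can leave the number within the scatter, whereas the values of compound 1 and compound 3 show that a different aryl group at that carbon can go with a far higher number. The step of a number 10.8 percentage points higher from compound 3 to compound 4 (beyond the scatter) is therefore expected to be modest and upward, with wide uncertainty. Compound 4 is estimated at 35%, within a range from 15% to 60%.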

Compound 4, a percentage reported as activity, at one concentration (the size of the read-out at that concentration, not a potency): 1.26%
Beside the measured number, compound 4's estimate is 33.7 percentage points above it; measured number below the stated range.
By their numbers in this assay, from the lowest: compound 4; then compounds 2 and 3 (each within the scatter of the next); then compound 1.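

In this assay, the carbon with a double bond to nitrogen now shows a number 22.9 percentage points lower from compound 3 to compound 4 (beyond the scatter) when 4-methylphenyl takes the place of 2,4-dichlorophenyl, and a number 17.4 percentage points lower from compound 2 to compound 4 (beyond the scatter) when it takes the place of 5-chloro-2-sulfamoylthiophen-3-yl. Among the compounds shown here, the only earlier step at this carbon lay within the scatter, so these are the first steps there to show a fall beyond it, and compound 4 stands lowest of the four. Methyl in place of phenyl on an aromatic carbon gives a number 58.9 percentage points lower from compound 1 to compound 4 (beyond the scatter) and is the largest step in the series, while no supporting data account for any of these steps and the cause stays unknown.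

The compounds shown leave open how an unsubstituted phenyl or a 4-chlorophenyl group would read at this carbon. They also leave open whether a longer chain, such as ethyl or propyl, in place of the methyl of compound 4 would move the number toward that of compound 1.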